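The source may report more compounds than this note shows. Statements on the series, on what has been measured and on what is new or still open speak of the compounds shown alone.

Compound 3, `O=C(c1ccccc1)N1CCC(NCCSC(c2ccc(F)cc2)c2ccc(F)cc2)CC1`, gives 2.03 nM in an assay on membranes from Cortex for displacement of a labelled ligand from Sigma non-opioid intracellular receptor 1 (Cavia porcellus), read by scintillation counting, with a stated time of 120 min (a higher number here means a weaker inhibitor, a lower number a stronger inhibitor), and so holds the lowest number of the three measured. Compound 1, `[O-][S+](CCNC1CCN(Cc2ccc(F)cc2)CC1)C(c1ccc(F)cc1)c1ccc(F)cc1`, gives 26.5 nM, and compound 2, `OC(Cc1ccccc1)CN1CCC(NCCSC(c2ccc(F)cc2)c2ccc(F)cc2)CC1`, gives 309 nM. Compound 4, `Fc1ccc(C(SCCNC2CCN(Cc3cc4ccccc4[nH]3)CC2)c2ccc(F)cc2)cc1`, is not yet measured; it differs from compound 3 in one place: (1H-indol-2-yl)methyl in place of benzoyl on an amine nitrogen in a ring. Among the compounds with values here, only one measured step bears on this position: a 150-fold lower number from compound 2 to compound 3 (2.18 log units; beyond the scatter), which shows that the group on that amine nitrogen can move the number a great deal. Within the data shown here, no measured step exchanges benzoyl for an arylmethyl group in isolation; compound 1 carries an arylmethyl group on the same nitrogen but also differs elsewhere, so its value against compound 3 is only a loose pointer toward a higher number. Compound 4 is therefore expected to give a moderately higher number, a step of a 7.4-fold higher number from compound 3 to compound 4 (0.87 log units; beyond the scatter), the estimate being 15 nM with a range from 3 nM to 80 nM.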

Compound 4, inhibition constant: 205 nM
Compound 4: middle estimate off by 14-fold (1.14 log units), on the low side; the measured number lies above the stated range.
By their numbers in this assay, from the lowest: compound 3; then compound 1; then compounds 4 and 2 (each within the scatter of the next).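

In this assay, the group on this amine nitrogen matters through more than its size: a 100-fold higher number from compound 3 to compound 4 (2.00 log units; beyond the scatter), although (1H-indol-2-yl)methyl, like benzoyl, carries aromatic rings. The second step, a 1.5-fold lower number from compound 2 to compound 4 (0.18 log units; within the scatter), puts two quite different groups, (1H-indol-2-yl)methyl and 2-hydroxy-3-phenylpropyl, at the same level within the scatter, so among compound 2, compound 3 and compound 4 only the benzoyl compound stands apart, with the lowest number. Nothing measured here accounts for this gap.

From the compounds shown here alone, whether the low number belongs to the carbonyl on the nitrogen or to benzoyl as a whole remains open, and an acetyl, benzenesulfonyl or plain benzyl group at this place would help to separate the two. Compound 1 differs from these compounds in more than one place, so its value cannot be read as a step at this position.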